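Replacing a chain amine by a piperidine ring

A few compounds are considered here, and "the series" means these few. Any claim that something is new, unique, unknown or untested is made for them only; others in the source may bear on it.

Compound 1 `O=C(Nc1nc(-c2ccncc2)c(CN2CCCCC2)s1)c1ccncc1`: 48.2%
Compound 2 `CC(C)N(C)Cc1sc(NC(=O)c2cccnc2)nc1-c1cccnc1`: 38.1%

In an assay on isolated protein for inhibition of Rho-associated protein kinase 2 (Homo sapiens), read by ELISA, with a stated time of 30 min, tested at 10 uM, in the presence of a further agent that is not named here (on this read-out higher numbers stand for more inhibition at the one concentration tested (going by the name of the read-out) and lower numbers for less inhibition), compound 2 gives the lower of the two numbers, and compound 1 stands higher by an amount beyond the usual scatter. Compound 3 `O=C(Nc1nc(-c2cccnc2)c(CN2CCCCC2)s1)c1cccnc1` differs from compound 2 in one place: piperidin-1-yl in place of isopropyl(methyl)amino on a saturated chain carbon bound to an aromatic carbon. Among the compounds with values here, no measured pair shows this change on its own. The step of a number 5.9 percentage points higher from compound 2 to compound 3 (within the scatter) is expected to be small and upward, at most about the scatter. Compound 3 is therefore expected to reach 44% in this assay, within a range from 30% to 58%.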

Compound 3, a percentage reported as inhibition, at one concentration (the size of the read-out at that concentration, not a potency): 28.5%
Estimate against measurement, compound 3: 15.5 percentage points above; the whole stated range lies above it.
By their numbers in this assay, from the lowest: compounds 3 and 2 (each within the scatter of the next); then compound 1.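

Within the data shown here, the step of a number 9.6 percentage points lower from compound 2 to compound 3 (within the scatter) is the first single change seen at this place, a saturated chain carbon bound to an aromatic carbon. In this assay, piperidin-1-yl therefore cannot be told apart from isopropyl(methyl)amino, so the ring and the open chain amine read alike on this core. Nothing shown explains these numbers.

From the compounds shown here alone, whether a morpholine or a dimethylamino group at this place would read apart from these two stays open. So does whether a longer chain between the amine and the core would change the reading.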